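Series notes: sulfur substituent on the shared core

The source may report more compounds than this note shows. Statements on the series, on what has been measured and on what is new or still open speak of the compounds shown alone.

Compound 3 `CC(Sc1nc2c(cnn2C)c(=O)n1-c1ccccc1)c1cncnc1` holds the highest number of the three measured in an assay on isolated protein for inhibition of retinal dehydrogenase 2 (Homo sapiens) (a lower number here means a stronger inhibitor, a higher number a weaker inhibitor), giving 380 nM. Its nearest neighbour is compound 2 `CCC(Sc1nc2c(cnn2C)c(=O)n1-c1ccccc1)c1ccccc1` at 179 nM, a gap of a 2.1-fold higher number from compound 2 to compound 3 (0.33 log units; beyond the scatter); the furthest is compound 1 `C[C@@H](Sc1nc2c(cnn2C)c(=O)n1-c1ccccc1)c1ccccc1` at 40 nM, a gap of a 9.5-fold higher number from compound 1 to compound 3 (0.98 log units; beyond the scatter). The step of a 4.5-fold higher number from compound 1 to compound 2 (0.65 log units; beyond the scatter) covers the other measured pair.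

Compound 4 `C[C@H](Sc1nc2c(cnn2C)c(=O)n1-c1ccccc1)c1ccccc1` carries the change (1-phenylethyl in place of 1-(pyrimidin-5-yl)ethyl on a sulfur). This is the reverse of the measured step from compound 1 to compound 3, but with one difference: compound 3 has no defined stereocentre, and the stereocentre in compound 4 is defined in the opposite sense to that in compound 1. Among the measured compounds shown here, no measured pair separates the two senses of this stereocentre, so how much of the gain seen in reversing a 9.5-fold higher number from compound 1 to compound 3 (0.98 log units; beyond the scatter) would carry over is unknown.

The expectation for compound 4 is a lower number than compound 3, estimated at 250 nM with a range of 50 nM to 1500 nM, a step of a 1.5-fold lower number from compound 3 to compound 4 (0.18 log units; within the scatter), the wide range reflecting the undetermined stereochemical outcome.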

Compound 4, half-maximal inhibitory concentration: 1480 nM
Compound 4: middle estimate off by 5.9-fold (0.77 log units), on the low side, within the range that was stated.
By their numbers in this assay, from the lowest: compound 1; then compound 2; then compound 3; then compound 4.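

The largest step in the series, a 37-fold higher number from compound 1 to compound 4 (1.57 log units; beyond the scatter), rests on the stereocentre alone, because of one fact: the fact that compounds 1 and 4 differ only in the configuration as drawn. The 1-phenylethyl group is therefore no gain in itself, since with the centre drawn S the step is a 3.9-fold higher number from compound 3 to compound 4 (0.59 log units; beyond the scatter), opposite in direction to a 9.5-fold higher number from compound 1 to compound 3 (0.98 log units; beyond the scatter). The step of an 8.3-fold higher number from compound 2 to compound 4 (0.92 log units; beyond the scatter) likewise places the S form behind 1-phenylpropyl, though compounds 2 and 3 carry no defined centre, so these two steps mix the change of group with the change in stereo definition.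

Open, going by these compounds, is how far the separate R and S forms of compounds 2 and 3 lie apart in this assay. Also open, on these data alone, is whether the preference for R holds for a longer chain such as 1-phenylbutyl or for a substituent bearing an amine.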